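Swapping Bromo for Trifluoromethyl on an Aromatic Carbon

This account rests on a few compounds, and the source may have more. Where it says the series, first, only, none or still open, it means among the compounds named here.

In a functional assay on U-251 cells (Homo sapiens) for cytotoxicity (on this read-out higher numbers stand for weaker inhibition of growth and lower numbers for stronger inhibition of growth), compound 1 `CSc1ccc(C2=C(c3ccc(O)cc3)C(=O)N3CCCC3C2)cc1` gives > 100000 nM, which is a limit of the assay and not a number. For the measured compounds named here, compound 2 `CSc1ccc(C2=C(c3ccc(Br)cc3)C(=O)N3CCCC3C2)cc1` gives 7000 nM, the only true number so far. Compound 3 `CSc1ccc(C2=C(c3ccc(C(F)(F)F)cc3)C(=O)N3CCCC3C2)cc1` carries trifluoromethyl in place of bromo on an aromatic carbon. Going by the values given here, the one measured step at this place, bromo in place of hydroxy, is large, an at least 14-fold lower number from compound 1 to compound 2 (1.15 log units; beyond the scatter), but it concerns hydroxy, which plays no part here, so a change beyond the scatter is not expected in this assay. The estimated step is a 1.1-fold higher number from compound 2 to compound 3 (0.06 log units; within the scatter). Compound 3 is expected at 8000 nM, within a range of 3000 nM to 25000 nM.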

Compound 3, concentration for 50% growth inhibition: 800 nM
For compound 3 the middle estimate is 10-fold (1.00 log units) above the measured one, outside the stated range (below it).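

In this assay, trifluoromethyl in place of bromo gives an 8.8-fold lower number from compound 2 to compound 3 (0.94 log units; beyond the scatter), so this position responds even to a swap between two groups with no hydrogen-bond donors or acceptors. Trifluoromethyl in place of hydroxy gives an at least 120-fold lower number from compound 1 to compound 3 (2.09 log units; beyond the scatter), which spans all three groups seen here. Compound 1 gives a limit of the assay and not a number: the limit of > 100000 nM in this assay, at which 1 of the 3 values shown sits.

Still open, as far as these compounds go, is how an amine, a nitrile or a carboxylic acid on this aromatic carbon would read. Three groups also cannot show whether any wider rule holds at this position.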